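Trimming the Amine: Benzyl Gives Way to Ethyl

The compounds below may be only part of what the source reports. "The series", "measured", "known", "first", "only" and "open" are said of these compounds alone.

Of the compounds shown here, two have so far been measured in an assay on cells for inhibition of Amine oxidase [flavin-containing] B (Homo sapiens), read by fluorescence, with a stated time of 30 min, tested at 10 uM; a higher number here means more inhibition at the concentration tested (going by the name of the read-out), a lower number less inhibition. Compound 1 `CCN(Cc1ccccc1)Cc1ccc(/C=C2\Oc3cc(OC)c(OC)cc3C2=O)cc1O` gives 23.9% in this assay, the lower of the two numbers recorded. Compound 2 `COc1cc2c(cc1OC)C(=O)/C(=C/c1ccc(O)cc1)O2`, built on the same core, gives 36.1% in this assay, and the gap between the two lies beyond the usual scatter. Compound 3 `CCN(CC)Cc1ccc(/C=C2\Oc3cc(OC)c(OC)cc3C2=O)cc1O` has not yet been measured. It differs from compound 1 in one place: methyl in place of phenyl on a saturated chain carbon bound to an amine nitrogen. Within the data shown here, no pair of measured compounds covers a change of this kind, so its effect cannot be read from the numbers in hand. Because compound 1 sits at 23.9%, only a modest shift is expected, and no step beyond the scatter is predicted in either direction. The expected step is a number 3.9 percentage points lower from compound 1 to compound 3 (within the scatter). Compound 3 is therefore estimated to give about 20%, within a range from 5% to 38%.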

Compound 3, a percentage reported as inhibition, at one concentration (the size of the read-out at that concentration, not a potency): 7.2%
Compound 3: the middle estimate sits 12.8 percentage points above what was measured, within the range that was stated.
By their numbers in this assay, from the lowest: compound 3; then compound 1; then compound 2.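

In this assay exchanging benzyl for ethyl on the amine nitrogen gives a number 16.7 percentage points lower from compound 1 to compound 3 (beyond the scatter) and so shows that the group at this place is not a neutral passenger on the shared core. Among these compounds, compound 1 and compound 3 form the first measured pair that isolates a change on this amine, and here the compound with the phenyl ring has the higher number. No measurement in hand explains this drop.

The compounds shown leave open whether the aromatic ring itself matters, which a cyclohexylmethyl group on the same nitrogen could test against benzyl. They also leave open how a longer link to the ring would read, as in a 2-phenylethyl group, or a ring that takes in the nitrogen, as in a morpholine.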